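The source may report more compounds than this note shows. Statements on the series, on what has been measured and on what is new or still open speak of the compounds shown alone.

Measured compounds:
compound 1 `CCOC(=O)[C@@]12C[C@@H]1[C@@H](n1cnc3c(NC)nc(C#Cc4ccc(Br)s4)nc31)[C@H](O)[C@@H]2O`: 6.42 nM in an assay on HEK-293T cells for displacement of a labelled ligand from transmembrane domain-containing protein TMIGD3 (Homo sapiens), read by scintillation counting and radioligand binding, with stated times of 10 min and 90 min; a lower number here means a stronger inhibitor, a higher number a weaker inhibitor
compound 2 `CCOC(=O)[C@@]12C[C@@H]1[C@@H](n1cnc3c(NC)nc(C#Cc4ccc(Cl)s4)cc31)[C@H](O)[C@@H]2O`: 169 nM
compound 3 `CCCOC(=O)[C@@]12C[C@@H]1[C@@H](n1cnc3c(NC)nc(C#Cc4ccc(Cl)s4)nc31)[C@H](O)[C@@H]2O`: 5.78 nM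

Among these three, compound 3 shows the lowest number in this assay, but its gap to compound 1 lies within the scatter, so these two cannot be placed in order. Compound 2 sits far higher than both, beyond the scatter. Compound 4 `CNc1nc(C#Cc2ccc(Cl)s2)nc2c1ncn2[C@H]1[C@H](O)[C@H](O)[C@]2(C(=O)OC(C)C)C[C@H]12` has not yet been measured. It differs from compound 3 in one place: isopropyl in place of propyl on an oxygen next to a carbonyl group. For the measured compounds named here, no measured pair shows what such a change does here, and the shape of the ester group is the only thing altered, so no step beyond the scatter is expected in either direction. Compound 4 is therefore expected to give about 7 nM in this assay, with a likely range from 2.5 nM to 20 nM. The expected step is a 1.2-fold higher number from compound 3 to compound 4 (0.08 log units; within the scatter), essentially flat.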

Compound 4, inhibition constant: 42.9 nM
The estimate for compound 4 lay 6.1-fold (0.79 log units) below the measured number; measured number above the stated range.
By their numbers in this assay, from the lowest: compounds 3 and 1 (each within the scatter of the next); then compound 4; then compound 2.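

In this assay, this ester position proves sensitive to how its chain is arranged: isopropyl in place of propyl on an oxygen next to a carbonyl group gives a 7.4-fold higher number from compound 3 to compound 4 (0.87 log units; beyond the scatter). Both groups hold the same atoms, so rearranging them alone moves the number beyond the scatter. Nothing available explains why this happens.

This rests on a single pair of compounds. On these data alone, whether a tert-butyl group or a longer chain such as butyl on the same oxygen would raise or lower the number remains open.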